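From Amide to Urea: Expecting Compound 4

The compounds below may be only part of what the source reports. "The series", "measured", "known", "first", "only" and "open" are said of these compounds alone.

Compound 3 `COc1cc(-c2nn(-c3cccc(NC(=O)c4ccc(Cl)c(C(F)(F)F)c4)c3)cc2-c2ccncc2)ccc1Cl` gives 1920 nM in a functional assay on LOX IMVI cells (Homo sapiens) for inhibition, read by sulforhodamine B assay, with a stated time of 48 h (a lower number here means a stronger inhibitor of growth, a higher number a weaker inhibitor of growth), the highest of the three measured numbers, though its gap to compound 1 is within the scatter. Compound 1 `COc1cc(-c2nn(-c3cccc(NC(=O)Nc4ccc(Cl)c(Cl)c4)c3)cc2-c2ccncc2)ccc1Cl` gives 954 nM and compound 2 `COc1cc(-c2nn(-c3cccc(NC(=O)Nc4cccc(C(F)(F)F)c4)c3)cc2-c2ccncc2)ccc1Cl` gives 789 nM. Compound 4 `COc1cc(-c2nn(-c3cccc(NC(=O)Nc4ccc(Cl)c(C(F)(F)F)c4)c3)cc2-c2ccncc2)ccc1Cl` differs from compound 3 by (4-chloro-3-(trifluoromethyl)phenyl)amino in place of 4-chloro-3-(trifluoromethyl)phenyl on a carbonyl carbon, which turns the amide into a urea. Among the measured compounds shown here, two measured steps bear on this, each running from a urea to an amide: a 2.0-fold higher number from compound 1 to compound 3 (0.30 log units; within the scatter) and a 2.4-fold higher number from compound 2 to compound 3 (0.39 log units; beyond the scatter). Reversing that direction, a lower number is expected for compound 4, by a step of roughly a 2.3-fold lower number from compound 3 to compound 4 (0.35 log units; beyond the scatter). Compound 4 is estimated at 850 nM, with a range from 400 nM to 1800 nM.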

Compound 4, concentration for 50% growth inhibition: 1170 nM
Estimate against measurement, compound 4: 1.4-fold (0.14 log units) below, within the range that was stated.
By their numbers in this assay, from the lowest: compounds 2, 1, 4 and 3 (each within the scatter of the next, the first and the last beyond it).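

In this assay, the urea of compound 4 and the amide of compound 3 carry the same 4-chloro-3-(trifluoromethyl)phenyl group, and a 1.6-fold lower number from compound 3 to compound 4 (0.22 log units; within the scatter) shows that the change on this carbonyl carbon alone stays within the scatter. Among the ureas, a 1.5-fold higher number from compound 2 to compound 4 (0.17 log units; within the scatter) for chloro in place of hydrogen and a 1.2-fold higher number from compound 1 to compound 4 (0.09 log units; within the scatter) for trifluoromethyl in place of chloro are also too small to separate these compounds. Nothing measured here gives a cause for these steps. From the compounds shown here alone, a carboxylic acid or a dimethylamino group on this phenyl ring remains open, as does whether either would move the number beyond the scatter.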